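A few compounds are considered here, and "the series" means these few. Any claim that something is new, unique, unknown or untested is made for them only; others in the source may bear on it.

Working notes on the series. Of the compounds shown here, two carry numbers so far. Compound 2 `Cn1c(-c2ccccc2)c(C#N)c2c(N)ncnc21` gives 30 nM in an assay on isolated protein for binding affinity to Leucine-rich repeat serine/threonine-protein kinase 2 (Homo sapiens), read by TR-FRET and LanthaScreen, with a stated time of 2 h (on this read-out higher numbers stand for weaker inhibition and lower numbers for stronger inhibition), the lower of the two values. Compound 1 `Cn1c(NCc2ccccc2)c(C#N)c2c(N)ncnc21` gives 423 nM in this assay, and the gap between compound 1 and compound 2 lies beyond the usual scatter of the read-out, so compound 2 stands as the stronger of the pair on the numbers in hand.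

The next compound is compound 3 `Cn1c(N)c(C#N)c2c(N)ncnc21`, which is not yet measured. Relative to compound 2 the change is amino in place of phenyl on an aromatic carbon. Going by the values given here, no pair of measured compounds differs in this single place, so no measured step can be transferred directly; the two values in hand show only that compound 1, which carries a benzylamino group at this carbon, sits well above compound 2.

The whole phenyl is removed and a single nitrogen is put in its place. The expectation is a loss in this assay beyond the scatter, a step estimated as a 20-fold higher number from compound 2 to compound 3 (1.30 log units; beyond the scatter). Compound 3 is therefore expected near 600 nM in this assay, with a range from 120 nM to 3000 nM.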

Compound 3, inhibition constant: 346 nM
The estimate for compound 3 lay 1.7-fold (0.24 log units) above the measured number, and the stated range covers the measured number.
By their numbers in this assay, from the lowest: compound 2; then compounds 3 and 1 (each within the scatter of the next).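

In this assay, the step of a 12-fold higher number from compound 2 to compound 3 (1.06 log units; beyond the scatter) lies beyond the scatter and is large, so the group on this aromatic carbon, next to the ring nitrogen, clearly affects the read-out, and amino does not retain the number given by phenyl. The step of a 1.2-fold lower number from compound 1 to compound 3 (0.09 log units; within the scatter) lies within the scatter, so hydrogen and benzyl on the nitrogen cannot be told apart here, and among these three compounds only compound 2, with phenyl on the carbon, stands apart from the other two. No measurement in hand accounts for the gap that separates phenyl from amino at this position.

The compounds shown leave open whether the better number needs an aromatic ring directly on this carbon, or whether a cyclohexyl ring or a simple methyl group would serve as well as phenyl. They also leave open how far the number moves with a pyridyl ring or a fluorophenyl group here, and whether a phenylamino group, with the ring carried on the nitrogen without the benzyl carbon, follows compound 2 or compound 3.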